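Trifluoromethyl for methyl on a tosylated core at the assay limit

The source may report more compounds than this note shows. Statements on the series, on what has been measured and on what is new or still open speak of the compounds shown alone.

Measured compounds in a functional assay on A549 cells (Homo sapiens) for cytotoxicity, read by MTT assay, with a stated time of 4 days; on this read-out higher numbers stand for weaker inhibition and lower numbers for stronger inhibition:
compound 1, `C=C1C(=O)[C@]23C[C@@]1(O)CC[C@H]2c1ccc(O)c(C)c1[C@@H]3Cn1cc(-c2ccc(C(F)(F)F)cc2)nn1`, gives 1110 nM;
compound 2, `C=C1C(=O)[C@]23C[C@@]1(O)CC[C@H]2c1ccc(O)c(C)c1[C@@H]3Cn1cc(-c2ccc(C)cc2)nn1`, gives 1260 nM;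
compound 3, `Cc1ccc(-c2cn(C[C@H]3c4c(ccc(OS(=O)(=O)c5ccc(C)cc5)c4C)[C@@H]4CC[C@@]5(C)C[C@]43CC5=O)nn2)cc1`, gives only a limit of the assay, > 20000 nM.

Compound 1 and compound 2 share one core and differ by trifluoromethyl in place of methyl on an aromatic carbon; this step reads a 1.1-fold lower number from compound 2 to compound 1 (0.06 log units; within the scatter). Compound 3 carries a different core, and the difference between the two cores is not broken down here. Compound 4, `Cc1ccc(S(=O)(=O)Oc2ccc3c(c2C)[C@H](Cn2cc(-c4ccc(C(F)(F)F)cc4)nn2)[C@@]24CC(=O)[C@@](C)(CC[C@@H]32)C4)cc1`, differs from compound 3 by trifluoromethyl in place of methyl on an aromatic carbon, the same change with the same place. Because compound 3 sits at the limit of > 20000 nM in this assay, at which 1 of the 3 values shown sits, and the measured step of a 1.1-fold lower number from compound 2 to compound 1 (0.06 log units; within the scatter) lies within the scatter, compound 4 is expected to move by a step that the limit leaves unreadable from compound 3 to compound 4, staying near that limit. Compound 4 is estimated at 25000 nM, between 12000 nM and 60000 nM, most likely reported as a limit rather than a number.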

Compound 4, half-maximal inhibitory concentration: > 20000 nM
Compound 4 was reported as a limit (the forecaster's own chance of this, stated with the estimate: 70%); the middle value is on the limit's open side.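

No step can be read from compound 3 to compound 4 in this assay because both stand only as limits: the limit of > 20000 nM in this assay, at which 2 of the 4 values shown sit. The compounds shown leave open whether trifluoromethyl in place of methyl changes anything on the core of compound 3.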